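Trimming the Hydroxyalkyl Chain Once More

The compounds below may be only part of what the source reports. "The series", "measured", "known", "first", "only" and "open" are said of these compounds alone.

In a functional assay on cells (Neutrophil, Homo sapiens) for inhibition, with a stated time of 10 min (on this read-out lower numbers stand for stronger inhibition and higher numbers for weaker inhibition), compound 3 `CCOC(=O)c1cnn(CC(O)CC)c1NC(=O)NC(C)C` gives 0.0042 nM, the middle of the three measured numbers. Compound 1 `CCCC(O)Cn1ncc(C(=O)OCC)c1NC(=O)NC(C)C` stands higher at 1 nM, and compound 2 `CCOC(=O)c1cnn(CC(C)O)c1NC(=O)Nc1cccc(F)c1` stands lower at 0.0007 nM. The next compound, compound 4 `CCOC(=O)c1cnn(CC(C)O)c1NC(=O)NC(C)C`, shortens the chain of compound 3: hydrogen in place of methyl on a saturated chain carbon, two bonds along the chain from an oxygen on a saturated carbon. Put simply, 2-hydroxybutyl becomes 2-hydroxypropyl.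

For the measured compounds named here, one measured step bears on this. The same swap of methyl for hydrogen, made three bonds along the chain from the oxygen rather than two, gave a 240-fold lower number from compound 1 to compound 3 (2.38 log units; beyond the scatter), a large move towards stronger inhibition. A single step is thin support, and nothing shows that its size carries over to a new place on the chain. Compound 2 also carries 2-hydroxypropyl, but it differs elsewhere too, so it offers only a loose hint. A smaller move in the same direction therefore seems likely in this assay, and the expected change is a 2.1-fold lower number from compound 3 to compound 4 (0.32 log units; beyond the scatter). For compound 4 the estimated value is 0.002 nM, with an expected range of 0.0003 nM to 0.02 nM.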

Compound 4, half-maximal inhibitory concentration: 0.00082 nM
Estimate against measurement, compound 4: 2.4-fold (0.39 log units) above; the measured number falls inside the stated range.
By their numbers in this assay, from the lowest: compounds 2 and 4 (each within the scatter of the next); then compound 3; then compound 1.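

In this assay the step from 2-hydroxybutyl to 2-hydroxypropyl gives a 5.1-fold lower number from compound 3 to compound 4 (0.71 log units; beyond the scatter) and so moves the same way as the earlier trim, which shows that the gain from shortening is not confined to the place three bonds along the chain from the oxygen. Across both trims, the full change gives a 1200-fold lower number from compound 1 to compound 4 (3.09 log units; beyond the scatter) and leaves 2-hydroxypropyl ahead of the two longer chains shown with isopropyl on the amide-type nitrogen. With 2-hydroxypropyl in place, the swap at that nitrogen gives a 1.2-fold higher number from compound 2 to compound 4 (0.07 log units; within the scatter) and lies within the usual scatter, so isopropyl and 3-fluorophenyl cannot be told apart here.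

From the compounds shown here alone, whether the trend continues to a 2-hydroxyethyl chain, or survives an amine in place of the hydroxyl, remains open. Nothing available explains why these chain changes move the number as they do.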